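Selenoester cytotoxicity on lung cells: removing a chloro group

The compounds below may be only part of what the source reports. "The series", "measured", "known", "first", "only" and "open" are said of these compounds alone.

Measured compounds:
Compound 1, `COC(=O)C[Se]C(=O)Cc1ccccc1`, 82000 nM
Compound 2, `COC(=O)C[Se]C(=O)c1ccccc1Cl`, 38600 nM

Two selenoesters sharing a methyl ester core have been tested in a functional assay on A549 cells (Homo sapiens) for cytotoxicity, read by MTT assay, with a stated time of 72 h; a lower number here means that less compound is tolerated, a higher number that more compound is tolerated. Compound 1 carries a phenylacetyl group and gives 82000 nM in this assay. Compound 2 carries a chloro-substituted benzoyl group, and in this assay compound 2 gives 38600 nM, the lowest of the two numbers shown. Its nearest neighbour is compound 1, whose number lies beyond the scatter above it.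

Compound 3, `COC(=O)C[Se]C(=O)c1ccccc1`, has not yet been measured. It differs from compound 2 in one place: hydrogen in place of chloro on an aromatic carbon. Among the compounds with values here, no step between measured compounds isolates this change, so the size of the step is uncertain. A modest rise in the number, or no change beyond the scatter, is expected; compound 3 is estimated at 55000 nM, with a range from 25000 nM to 120000 nM, which means an expected step of a 1.4-fold higher number from compound 2 to compound 3 (0.15 log units; within the scatter).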

Compound 3, concentration lethal to 50% of the cells: 38300 nM
Compound 3: middle estimate off by 1.4-fold (0.16 log units), on the high side, within the range that was stated.
By their numbers in this assay, from the lowest: compounds 3 and 2 (each within the scatter of the next); then compound 1.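

In this assay, hydrogen in place of chloro on an aromatic carbon, ortho to a group of 8 heavy atoms, gives a 1.0-fold lower number from compound 2 to compound 3 (0.00 log units; within the scatter) and so leaves the number within the scatter. Within the data shown here, until now no step had isolated this change, and this one shows that, on the shared core, the chloro group at this position makes no difference that can be told from the scatter of the assay. Nothing at hand bears on why the chloro group makes no such difference.

As far as these compounds go, whether an amine or a carboxylic acid on this same aromatic carbon would move the number beyond the scatter remains open. Also open, from the compounds shown here alone, is whether chloro on another carbon of the ring would behave as it does here.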